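A few compounds are considered here, and "the series" means these few. Any claim that something is new, unique, unknown or untested is made for them only; others in the source may bear on it.

Compound 2 `O=C1CS/C(=N/N=C/c2c[nH]c3ccccc23)N1c1cccc2ccccc12` reads > 100000 nM in a functional assay on NCI-H460 cells (Homo sapiens) for inhibition, read by spectrophotometry and sulforhodamine B assay, with a stated time of 48 h (on this read-out higher numbers stand for weaker inhibition of growth and lower numbers for stronger inhibition of growth), which is a limit of the assay and not a number. Going by the values given here, its place is therefore known only as a limit, and the values so far include (the limit of > 100000 nM in this assay, at which 1 of the 3 values shown sits). Compound 1 `Cc1ccc(N2C(=O)CS/C2=N/N=C/c2c[nH]c3ccc(Br)cc23)cc1`, which carries a bromo, gives 96600 nM in this assay. Compound 3 `S=C(N/N=C/c1c[nH]c2ccc(Br)cc12)Nc1cccc2ccccc12`, which also carries a bromo but on a different core, gives 6990 nM in this assay.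

The next compound is compound 4 `O=C1CS/C(=N/N=C/c2c[nH]c3ccc(Br)cc23)N1c1cccc2ccccc12`. It differs from compound 2 by bromo in place of hydrogen on an aromatic carbon, with bromo in place of hydrogen on an aromatic carbon. Among the compounds with values here, no measured pair isolates this change, so its size in this assay can only be judged indirectly. A modest step towards stronger inhibition of growth is expected, resting mainly on compound 1 at 96600 nM, with compound 3 at 6990 nM leaving some room for a larger one.

The expected change is an at least 1.8-fold lower number from compound 2 to compound 4 (0.25 log units; that floor lies within the scatter). For compound 4 the estimate is 55000 nM, with an expected range of 20000 nM to 100000 nM.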

Compound 4, concentration for 50% growth inhibition: > 100000 nM
Compound 4: no number, only a limit; the forecaster's own chance of this, stated with the estimate: 35%; middle value at least 1.8-fold (0.25 log units) from the limit.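

Compound 2 and compound 4 both give only a limit of the assay, so no step between them can be read: the limit of > 100000 nM in this assay, at which 2 of the 4 values shown sit.

From the compounds shown here alone, whether bromo in place of hydrogen on an aromatic carbon changes growth inhibition on the core shared by compound 2 and compound 4 in this assay stays open.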